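Swapping Fluoro for Methoxy on a Quiet Scaffold

A few compounds are considered here, and "the series" means these few. Any claim that something is new, unique, unknown or untested is made for them only; others in the source may bear on it.

Of the compounds shown here, three sharing one core have been tested for their power to kill a human colon cancer cell line in a functional assay on SW480 cells (Homo sapiens) for cytotoxicity, read by MTT assay, with a stated time of 24 h; a lower number here means a stronger inhibitor, a higher number a weaker inhibitor. Compound 1 `C=CC1=C(C(=O)Nc2ccccc2)C(c2ccc(Cl)c(Cl)c2)OC1` gives > 100000 nM in this assay, which is a limit of the assay rather than a measured number. Compound 2 `C=CC1=C(C(=O)NCc2ccc(Cl)cc2)C(c2ccc(OC)cc2)OC1` likewise gives > 100000 nM, again only a limit. As far as these compounds go, compound 3 `C=CC1=C(C(=O)Nc2ccccc2OC)C(c2ccc(F)cc2)OC1` reaches merely > 100000 nM, also a limit, so its true potency remains unknown. All three therefore rest together at the limit of > 100000 nM in this assay, at which 3 of the 3 values shown sit: none has shown measurable cytotoxicity within the tested range, and nothing separates one from another.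

Compound 4 `C=CC1=C(C(=O)Nc2ccccc2OC)C(c2ccc(OC)cc2)OC1` differs from compound 3 in a single place: methoxy in place of fluoro on an aromatic carbon. Compound 2 also carries a 4-methoxyphenyl group and gave only a limit.

Within the data shown here, no step between measured compounds exists here, so the expected size of the change from compound 3 to compound 4 in this assay rests on thin ground. With every measured value sitting at the limit, the expectation is no shift beyond the scatter, most likely another limit; the step is estimated as a step that the limit leaves unreadable from compound 3 to compound 4. Compound 4 is therefore expected to give around 150000 nM, within a range from 40000 nM to 600000 nM.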

Compound 4, half-maximal inhibitory concentration: > 100000 nM
Compound 4 gave a limit, no number; the forecaster's own chance of this, stated with the estimate: 85%; the middle value is on the limit's open side.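

No step can be read from compound 3 to compound 4, or from compound 2 to compound 4, because every compound gives only a limit, not a number: the limit of > 100000 nM in this assay, at which 4 of the 4 values shown sit.

The compounds shown leave open how far each lies beyond that limit in this assay, and whether any change to the shared core would give a measurable value.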